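The source may hold more compounds than are shown below. What is called first, only, known or untested is meant among the compounds shown, and "the series" means these compounds.

Among the compounds with values here, in a functional assay on MDA-MB-231 cells (Homo sapiens) for antiproliferative activity, read by MTT assay, with a stated time of 48 h (on this read-out higher numbers stand for weaker inhibition and lower numbers for stronger inhibition), two compounds with the same core have numbers so far. Compound 1 (`C=CS(=O)(=O)N1CCN(c2ncnc3sc(-c4ccc(OC)cc4)cc23)CC1`) gives 29900 nM and compound 2 (`C=CS(=O)(=O)N1CCN(c2ncnc3sc(-c4cn(S(=O)(=O)c5ccccc5)c5ccccc45)cc23)CC1`) gives 40400 nM there. These two values lie within the usual scatter of each other, so compound 1 stands level with compound 2. Compound 3 (`C=CS(=O)(=O)N1CCN(c2ncnc3sc(-c4cc(Br)cnc4F)cc23)CC1`) is still unmeasured. It keeps the core of compound 1 and swaps one group (5-bromo-2-fluoropyridin-3-yl in place of 4-methoxyphenyl on an aromatic carbon) on an aromatic carbon next to the ring sulfur, putting 5-bromo-2-fluoropyridin-3-yl in place of 4-methoxyphenyl. Within the data shown here, no measured pair shows this swap alone. Compound 2 also carries a different group at that place and still gives 40400 nM as its result, so no step beyond the scatter is expected in this assay for this change. The expected step is small (a 1.0-fold higher number from compound 1 to compound 3 (0.00 log units; within the scatter)) and its direction is open. For compound 3 the estimated value is 30000 nM with an expected range from 10000 nM to 80000 nM in this measurement.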

Compound 3, half-maximal inhibitory concentration: 24100 nM
Estimate against measurement, compound 3: 1.2-fold (0.10 log units) above; measured number inside the range.
By their numbers in this assay, from the lowest: compounds 3, 1 and 2 (each within the scatter of the next).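

In this assay, putting 5-bromo-2-fluoropyridin-3-yl in place of 4-methoxyphenyl on the aromatic carbon next to the ring sulfur gives a 1.2-fold lower number from compound 1 to compound 3 (0.09 log units; within the scatter) and so leaves the number level. Within the data shown here, this is the first direct reading of a single swap at this position, and it shows that a ring with a hetero atom carrying fluorine and bromine stands level here with a carbon-only ring carrying methoxy. No measurement shown here accounts for this result.

From the compounds shown here alone, all three compounds carry an aromatic ring at this place, so it remains open whether an amine, a carboxylic acid or a longer chain there would move the number beyond the scatter. Going by these compounds, what a change elsewhere on the shared core would do also remains open.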